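The source may report more compounds than this note shows. Statements on the series, on what has been measured and on what is new or still open speak of the compounds shown alone.

Measured so far:
compound 1 `C=CC(=O)NCc1coc(-c2c(N)ncnc2Nc2ccc(OCc3ccccn3)c(F)c2)n1`, 0.45 h in an in vitro ADME assay on microsomes from liver (Homo sapiens) for metabolic stability, tested at 5 uM; on this read-out higher numbers stand for a longer-lived compound and lower numbers for a shorter-lived compound
compound 2 `C=CC(=O)NCc1coc(-c2c(N)ncnc2Nc2ccc(Oc3cc(Cl)ccc3Cl)c(Cl)c2)n1`, 1.6 h in this assay

Compound 2 stands highest of the two numbers; the nearest, compound 1, sits lower by a gap beyond the usual scatter. Compound 3 `C=CC(=O)NCc1coc(-c2c(N)ncnc2Nc2ccc(Oc3cccnc3)c(Cl)c2)n1` differs from compound 2 in one place: pyridin-3-yl in place of 2,5-dichlorophenyl on an oxygen on an aromatic ring. Within the data shown here, no step between measured compounds covers this change, so the direction rests on the two numbers alone. Compound 1 gives 0.45 h in this assay. A downward step a 2.3-fold lower number from compound 2 to compound 3 (0.36 log units; beyond the scatter) is expected, towards that lower number. Compound 3 is estimated at 0.7 h, with a range from 0.3 h to 1.6 h.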

Compound 3, half-life: 0.25 h
Compound 3: middle estimate off by 2.8-fold (0.45 log units), on the high side, and the stated range ends above it.
By their numbers in this assay, from the lowest: compounds 3 and 1 (each within the scatter of the next); then compound 2.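

On an oxygen on an aromatic ring, the group held there clearly moves the read-out in this assay: pyridin-3-yl in place of 2,5-dichlorophenyl gives a 6.4-fold lower number from compound 2 to compound 3 (0.81 log units; beyond the scatter). Among these compounds, this is the first single-place comparison, but one pair sets no trend. Nothing available explains the size of this step.

Still open, on these data alone, is whether the step follows the loss of the two chlorines or the entry of the ring nitrogen, as both change together. An unsubstituted phenyl on the same oxygen would separate the two.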